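Trading a free amine for an azide on the side chain

The compounds below may be only part of what the source reports. "The series", "measured", "known", "first", "only" and "open" are said of these compounds alone.

The series shares one core, borne by compound 1 `Cn1c(=O)c2c(Cl)cccc2c(=O)n1CCCNC(=O)OC(C)(C)C`, compound 2 `Cn1c(=O)c2cccc(Cl)c2c(=O)n1CCCNC(=O)OC(C)(C)C` and compound 3 `Cn1c(=O)c2c(Cl)cccc2c(=O)n1CCCN`. In a functional assay on aorta (Rattus norvegicus, strain Wistar) for inhibition (on this read-out higher numbers stand for an effect only at larger amounts of compound and lower numbers for an effect already at smaller amounts), compound 1 gives 2150 nM, compound 2 gives 4780 nM and compound 3 gives 8510 nM. On these numbers compound 3 stands highest of the three; its gap to compound 2 lies within the scatter, while its gap to compound 1 lies beyond it. Within the data shown here, the one step that can be read within the set is a 4.0-fold higher number from compound 1 to compound 3 (0.60 log units; beyond the scatter). The compound that follows is compound 4 `Cn1c(=O)c2c(Cl)cccc2c(=O)n1CCN=[N+]=[N-]`. The change from compound 3 is azido in place of aminomethyl on a saturated chain carbon, two bonds along the chain from an aromatic nitrogen. Among the measured compounds shown here, no measured step matches this change directly; the only step in hand exchanges a tert-butoxycarbonyl-bearing amine for a free amine, and compound 4 again removes the free amine, now in favour of azido, with the chain one atom shorter. Since compound 1 without the free amine stands at 2150 nM, a modest move back toward lower numbers is expected, though with wide uncertainty. The estimated step is a 1.9-fold lower number from compound 3 to compound 4 (0.28 log units; within the scatter). Compound 4 is thus expected near 4500 nM, within about 1500 nM to 14000 nM.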

Compound 4, half-maximal effective concentration: 4120 nM
Compound 4: the middle estimate sits 1.1-fold (0.04 log units) above what was measured, and the stated range covers the measured number.
By their numbers in this assay, from the lowest: compounds 1, 4, 2 and 3 (each within the scatter of the next, the first and the last beyond it).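

In this assay, azido in place of aminomethyl on a saturated chain carbon, two bonds along the chain from an aromatic nitrogen, gives a 2.1-fold lower number from compound 3 to compound 4 (0.32 log units; beyond the scatter), so this end of the side chain can be rebuilt without losing the effect. Among these compounds, until now, the only reading at this end of the chain was the removal of tert-butoxycarbonyl from the amine nitrogen, which gave a 4.0-fold higher number from compound 1 to compound 3 (0.60 log units; beyond the scatter); the free amine now stands higher than two different replacements, a carbamate and an azide, and the entering azido group carries no hydrogen-bond donor where the aminomethyl carried one. Compound 2 also lacks the free amine, but it differs from compound 3 in more than one place and so neither supports this reading nor counts against it.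

The compounds shown leave open how much of the step belongs to the azido group and how much to the shorter chain, since the same difference also reads 3-aminopropyl to 2-azidoethyl; a 2-aminoethyl chain or a 3-azidopropyl chain on the same core would separate the two, and a carboxylic acid at the chain end would test a further kind of group. Nothing in hand accounts for the size of the step.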